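This account rests on a few compounds, and the source may have more. Where it says the series, first, only, none or still open, it means among the compounds named here.

Measured so far in an ADME assay on microsomes from liver (Mus musculus) for metabolic stability, read by LC-MS, with a stated time of 10 min, tested at 0.5 uM; a higher number here means that more of the compound is left, a lower number that less of the compound is left:
- compound 1 `c1ccc2c(c1)CN[C@@H](CN(CCCN1CCNCC1)[C@H]1CCCc3cccnc31)C2` gives 92%
- compound 2 `c1cnc2c(c1)CN[C@@H](CN(CCCN1CCNCC1)[C@H]1CCCc3cccnc31)C2` gives 78%

Compound 2 stands at 78% and holds the lower of the two numbers. Compound 3 `c1cnc2c(c1)CCC[C@@H]2N(CCCN1CCNCC1)Cc1nc2ccccc2s1` differs from compound 2 through a group of 9 heavy atoms (7 carbon, 1 nitrogen, 1 sulfur; one five-membered aromatic ring with 2 hetero atoms, one six-membered aromatic ring of carbon only) in place of a group of 10 heavy atoms (8 carbon, 2 nitrogen; one six-membered non-aromatic ring with 1 hetero atom, one six-membered aromatic ring with 1 hetero atom), on a saturated chain carbon bound to an amine nitrogen and the new group is 1,3-benzothiazol-2-yl. For the measured compounds named here, only one measured step bears on this change, at the same place: a number 14 percentage points lower from compound 1 to compound 2 (beyond the scatter) and it lies beyond the scatter. That step altered less of the group than the change to compound 3 does, so its size is only a rough guide. Going by the values given here, no measurement yet covers 1,3-benzothiazol-2-yl, so the direction is a tentative call. The expected change is a number 13 percentage points lower from compound 2 to compound 3 (beyond the scatter) and it remains uncertain. For compound 3 the estimated value is 65% with an expected range of 40% to 88% around it.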

Compound 3, percent of the compound remaining: 45%
Beside the measured number, compound 3's estimate is 20 percentage points above it; the measured number falls inside the stated range.
By their numbers in this assay, from the lowest: compound 3; then compound 2; then compound 1.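

On a saturated chain carbon bound to an amine nitrogen, the choice of group can matter much more in this assay than the earlier pair suggested: 1,3-benzothiazol-2-yl gives a number 33 percentage points lower from compound 2 to compound 3 (beyond the scatter) and, against 1,2,3,4-tetrahydroisoquinolin-3-yl, a number 47 percentage points lower from compound 1 to compound 3 (beyond the scatter) in this read-out. Both steps are larger than a number 14 percentage points lower from compound 1 to compound 2 (beyond the scatter), so replacing the whole group moves the number further here than the smaller change did. Nothing available explains these drops.

The new group brings sulfur and a five-membered aromatic ring and loses the non-aromatic ring all at once, so these changes cannot be told apart. A 1,3-benzoxazol-2-yl, with oxygen in place of sulfur, or a plain phenyl group at this place would help separate them.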